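This account rests on a few compounds, and the source may have more. Where it says the series, first, only, none or still open, it means among the compounds named here.

Within the data shown here, in a functional assay on SW480 cells (Homo sapiens) for antiproliferative activity, read by MTT assay, with a stated time of 48 h (a lower number here means a stronger inhibitor, a higher number a weaker inhibitor), compound 2 (`CCCCCCCC(CCO)n1cnc2c(Cl)ncnc21`) gives 3630 nM, the only number so far. Compound 1 (`CCC(CCO)n1cnc2c(Cl)ncnc21`) gives > 50000 nM, which is a limit and not a number. Compound 3 (`OCCC(CO)n1cnc2c(Cl)ncnc21`) differs from compound 2 by hydroxy in place of hexyl on a saturated chain carbon, two bonds along the chain from an aromatic nitrogen. Among the measured compounds shown here, the one measured step that bears on this is an at least 13-fold lower number from compound 1 to compound 2 (1.13 log units; beyond the scatter), where pentyl replaced hydrogen. For the measured compounds named here, with that step as the only guide, a large move to a higher number is expected in this assay. The expected step is a 14-fold higher number from compound 2 to compound 3 (1.14 log units; beyond the scatter). For compound 3 the estimate is 50000 nM, with an expected range of 12000 nM to 200000 nM.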

Compound 3, half-maximal inhibitory concentration: > 50000 nM
Compound 3 ended at the assay's limit; the forecaster's own chance of this, stated with the estimate: 65%; the middle value lies on the limit itself.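

In this assay, hydroxy in place of hexyl on a saturated chain carbon, two bonds along the chain from an aromatic nitrogen, gives an at least 13-fold higher number from compound 2 to compound 3 (1.13 log units; beyond the scatter). Compound 3 gives > 50000 nM, which is a limit and not a number. Of the compounds shown, only compound 2, with the long chain, gives a readable number, and the step between compound 1 and compound 3 cannot be read: the limit of > 50000 nM in this assay, at which 2 of the 3 values shown sit.

Open, as far as these compounds go, is whether a chain longer than that of compound 2 would lower the number further. Also open, from the compounds shown here alone, is how an amine or a carboxylic acid would read in this place.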